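Amide-nitrogen substituent variation in a lipopeptide series

A few compounds are considered here, and "the series" means these few. Any claim that something is new, unique, unknown or untested is made for them only; others in the source may bear on it.

Measured so far in an assay on HEK293 cells for agonist activity at Toll-like receptor 2 (Homo sapiens); on this read-out higher numbers stand for an effect only at larger amounts of compound and lower numbers for an effect already at smaller amounts:
- compound 1 `CCCCCCCCCCCC(=O)OC[C@H](CSC[C@@H](N)C(=O)NC(C)(C)CO)OC(=O)CCCCCCCCCCC`: 15500 nM
- compound 2 `CCCCCCCCCCCC(=O)OC[C@H](CSC[C@@H](N)C(=O)N[C@H](C)CO)OC(=O)CCCCCCCCCCC`: 22200 nM
- compound 3 `CCCCCCCCCCCC(=O)OC[C@H](CSC[C@@H](N)C(=O)N[C@@H](CC)COCC(=O)O)OC(=O)CCCCCCCCCCC`: 6500 nM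

Compound 3 gives the lowest number of the three; the step to it from compound 1 is a 2.4-fold lower number from compound 1 to compound 3 (0.38 log units; beyond the scatter) and from compound 2 is a 3.4-fold lower number from compound 2 to compound 3 (0.53 log units; beyond the scatter). Between compounds 1 and 2 the step is a 1.4-fold higher number from compound 1 to compound 2 (0.16 log units; within the scatter), so the two hydroxymethyl-bearing substituents are not separated by the data.

Compound 4 `CCCCCCCCCCCC(=O)OC[C@H](CSC[C@@H](N)C(=O)NCCCCN)OC(=O)CCCCCCCCCCC` is not yet measured. The change is 4-aminobutyl in place of 1-((carboxymethoxy)methyl)propyl on an amide-type nitrogen. Both measured steps that bear on this position show that the 1-((carboxymethoxy)methyl)propyl group goes with a lower number than either hydroxymethyl-bearing group. Within the data shown here, removing it and putting in 4-aminobutyl has no direct precedent here; the nearest guide is that the other substituents sit higher than compound 3. Among the measured compounds shown here, the expected step is therefore a modest rise, a 2.0-fold higher number from compound 3 to compound 4 (0.30 log units; within the scatter), with wide uncertainty since 4-aminobutyl resembles none of the measured groups.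

Compound 4 is estimated at 13000 nM in this assay, within a range of 4000 nM to 45000 nM.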

Compound 4, half-maximal effective concentration: 1040 nM
Estimate against measurement, compound 4: 13-fold (1.10 log units) above; the whole stated range lies above it.
By their numbers in this assay, from the lowest: compound 4; then compound 3; then compounds 1 and 2 (each within the scatter of the next).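

In this assay this position on the amide-type nitrogen spans a wider range than the first three compounds showed: 4-aminobutyl in place of 1-((carboxymethoxy)methyl)propyl gives (a 6.3-fold lower number from compound 3 to compound 4 (0.80 log units; beyond the scatter)). Against the two hydroxymethyl-bearing substituents, the same group gives (a 21-fold lower number from compound 2 to compound 4 (1.33 log units; beyond the scatter)) and (a 15-fold lower number from compound 1 to compound 4 (1.17 log units; beyond the scatter)), so the lowest number in the set now goes with an unbranched chain ending in an amine. Nothing available accounts for these steps.

Still open, from the compounds shown here alone, is whether the terminal amine or the four-carbon chain goes with the lower number; a butyl chain ending in a hydroxyl or a carboxylic acid would separate the two. Also open, going by these compounds, is how chain length counts, which 3-aminopropyl and 5-aminopentyl would address.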